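Methyl to Methoxy: Expecting Compound 3

A few compounds are considered here, and "the series" means these few. Any claim that something is new, unique, unknown or untested is made for them only; others in the source may bear on it.

Compound 2 `Cc1ccccc1/C=N/NC(N)=S` and compound 1 `Cc1cccc(/C=N/NC(N)=S)c1` are measured in a functional assay on B16 cells (Mus musculus) for inhibition, tested at 10 uM; on this read-out higher numbers stand for more inhibition at the one concentration tested (going by the name of the read-out) and lower numbers for less inhibition. In this assay compound 2 gives > 100%, which is a limit of the assay and not a number. In this assay compound 1 also gives > 100%, again a limit. Among the compounds with values here, both values sit at the limit of > 100% in this assay, at which 2 of the 2 values shown sit, so no measured step between them can be sized. Compound 3 `COc1ccccc1/C=N/NC(N)=S` differs from compound 2 by methoxy in place of methyl on an aromatic carbon. With nothing to lean on, no step beyond the scatter is expected. Compound 3 is therefore expected to give 100%, in the range 85% to 100%. The expected step is a number no higher from compound 2 to compound 3 (the limit leaves the size open).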

Compound 3, a percentage reported as inhibition, at one concentration (the size of the read-out at that concentration, not a potency): 52%
Compound 3: the middle estimate sits 48 percentage points above what was measured; the whole stated range lies above it.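

In this assay, methoxy in place of methyl on an aromatic carbon gives a number at least 48 percentage points lower from compound 2 to compound 3 (beyond the scatter). Within the data shown here, this position therefore responds to a single small change, something the earlier compounds could not show while both sat at a limit. The true size of the step stays unknown, as the value of compound 2 is a limit and not a number: the limit of > 100% in this assay, at which 2 of the 3 values shown sit.

Which feature of methoxy matters remains open. So does how an amine or a longer chain at this place would read in this assay.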